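The compounds below may be only part of what the source reports. "The series", "measured", "known", "first", "only" and "open" are said of these compounds alone.

Compound 1, `CN1CCC(Cn2nc(Cc3ccc(Cl)cc3)c3ccccc3c2=O)C1`, gives 79.4 nM in an assay for binding affinity to Alpha-1B adrenergic receptor (Homo sapiens); on this read-out higher numbers stand for weaker inhibition and lower numbers for stronger inhibition.
Compound 2, `CCCCCc1nn(C[C@H]2CCCN2C)c(=O)c2ccccc12`, gives 1000 nM in this assay.
Compound 3, `CN1CCC[C@@H]1Cn1nc(Cc2ccc(C(C)(C)C)cc2)c2ccccc2c1=O`, reaches only a limit in this assay, > 1990 nM.

Of the two compounds that give a number in this assay, compound 2 stands highest; compound 1 sits a good deal lower, a gap that lies beyond the usual scatter. Compound 3 yields no number, only a limit, (the limit of > 1990 nM in this assay, at which 1 of the 3 values shown sits).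

Compound 4, `CN1CCC[C@@H]1Cn1nc(CC2CCCCC2)c2ccccc2c1=O`, has not yet been measured. It differs from compound 2 in one place: cyclohexyl in place of butyl on a saturated chain carbon bound to an aromatic carbon. Among the compounds with values here, no measured pair of compounds shows this change by itself, so the size of the step must be judged from what the three measured compounds show. Compound 1, carrying a substituted aromatic ring at the same chain carbon, sits well below compound 2, while compound 3, with a bulkier aromatic group there, gives only a limit. A saturated six-membered ring lies between these cases in character, and a step of modest size in either direction, or none beyond the scatter, is plausible. For compound 4 the expected value in this assay is 630 nM, with a range from 160 nM to 2500 nM. That estimate means a step of a 1.6-fold lower number from compound 2 to compound 4 (0.20 log units; within the scatter), which is expected to stay near the scatter.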

Compound 4, inhibition constant: > 1990 nM
Compound 4: a limit, no number; the forecaster's own chance of this, stated with the estimate: 25%; at least 3.1-fold (0.49 log units) between middle value and limit.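

In this assay compound 4 reaches only a limit, > 1990 nM, and gives no number. Replacing butyl with cyclohexyl on a saturated chain carbon bound to an aromatic carbon amounts to an at least 1.9-fold higher number from compound 2 to compound 4 (0.29 log units; that floor lies within the scatter), so this pair gives only a floor for the step, and whether the true step clears the usual scatter cannot be read from it. This is the first one-place change shown at this position, and it gives no sign that cyclohexyl lowers the number; compound 4 also ends at the same limit as compound 3, which carries a substituted aromatic ring on the same chain carbon: the limit of > 1990 nM in this assay, at which 2 of the 4 values shown sit.

Since compound 3 and compound 4 both stop at a limit, their order cannot be read, and neither can the real size of the step from compound 2 to compound 4. The compounds shown also leave open how this position would respond to a smaller ring such as cyclopropyl, or to a butyl chain ending in an amine or a hydroxyl group, in place of cyclohexyl on this chain carbon.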